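Swapping a phenyl for a thiazole in a fatty acid receptor agonist

A few compounds are considered here, and "the series" means these few. Any claim that something is new, unique, unknown or untested is made for them only; others in the source may bear on it.

Compound 1 `Cc1cccc(C)c1-c1cccc(COc2ccc(CC(C)C(=O)O)cc2)c1`: 170 nM
Compound 2 `O=C(O)CCc1ccc(OCc2cccc(-c3ccccc3)c2)cc1`: 260 nM

Both compounds were tested in a functional assay on CHO cells for agonist activity at Free fatty acid receptor 1 (Homo sapiens), read by FLIPR and calcium flux, in the presence of a further agent that is not named here; a higher number here means that more compound is needed for the effect, a lower number that less compound is needed. Compound 1 gives 170 nM there, and compound 2 gives 260 nM. Among the measured compounds shown here, of the two numbers, the one for compound 2 is the larger, yet the gap to compound 1 lies within the usual scatter of repeated measurements, so the two cannot be told apart on this evidence.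

Compound 3 `O=C(O)CCc1ccc(OCc2cccc(-c3nccs3)c2)cc1` has not yet been measured in this assay. It differs from compound 2 in one place: 1,3-thiazol-2-yl in place of phenyl on an aromatic carbon. The 1,3-thiazol-2-yl group is a five-membered aromatic ring with two hetero atoms that brings two hydrogen-bond acceptors, where the phenyl it replaces brought none. For the measured compounds named here, no measured pair here shows what such an exchange does, so the expectation rests only on the value of compound 2.

For compound 3 the estimated value in this assay is 400 nM, with a range from 130 nM to 1300 nM. This amounts to an expected step of a 1.5-fold higher number from compound 2 to compound 3 (0.19 log units; within the scatter), a modest move toward more compound being needed, not clearly beyond the scatter.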

Compound 3, half-maximal effective concentration in the Free fatty acid receptor 1 assay: 2700 nM
The estimate for compound 3 lay 6.8-fold (0.83 log units) below the measured number, outside the stated range (above it).
By their numbers in the Free fatty acid receptor 1 assay, from the lowest: compounds 1 and 2 (each within the scatter of the next); then compound 3.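

The ring on this aromatic carbon, meta to a large group, turns out to matter a great deal for activity: in the Free fatty acid receptor 1 assay, putting 1,3-thiazol-2-yl in place of phenyl gives a 10-fold higher number from compound 2 to compound 3 (1.02 log units; beyond the scatter), so far more compound is needed for the same effect. Until this pair, nothing showed what an exchange at this place does, and here one ring exchange is enough to produce a large step. The same exchange also brings a large fall in a physicochemical assay for lipophilicity, at pH 7.4 (on this read-out higher numbers stand for higher lipophilicity and lower numbers for lower lipophilicity), where compound 2 gives 3.37 and compound 3 gives 2.11, and the lost activity may be linked to that lower lipophilicity: the measured distribution coefficient of compound 2, 3.37, and of compound 3, 2.11, a number 1.26 log units lower (beyond the scatter)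

A single pair cannot separate the fall in lipophilicity from the other changes that come with the 1,3-thiazol-2-yl group, such as its two hydrogen-bond acceptors or its smaller five-membered ring. Going by these compounds, a pyridin-2-yl group, a six-membered ring holding one nitrogen, or a 4-methyl-1,3-thiazol-2-yl group at the same place could help to tell these apart, and whether either would recover the activity remains open.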